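The compounds below may be only part of what the source reports. "The series", "measured", "known", "first", "only" and "open" are said of these compounds alone.

Working notes on the series. In a functional assay on HTB-54 cells (Homo sapiens) for cytotoxicity, read by MTT assay, with a stated time of 72 h (on this read-out lower numbers stand for stronger inhibition of growth and higher numbers for weaker inhibition of growth), compound 2 `CSc1ccc(CNc2nc([SeH])nc3ccccc23)cc1` gives 45500 nM. Compound 1 `CCCCC[Se]c1nc(NCc2ccc(SC)cc2)c2ccccc2n1` carries pentyl in place of hydrogen on a selenium relative to compound 2; in this assay compound 1 gives 40400 nM, and the step of a 1.1-fold lower number from compound 2 to compound 1 (0.05 log units; within the scatter) lies within the scatter. Compound 3 `Nc1nc([SeH])nc2ncccc12` rests on a different core; the difference between the two cores is not broken down here. In this assay compound 3 gives 44300 nM, which sits within the scatter of both compound 1 and compound 2, so no order among the three can be read.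

Compound 4 `CCCCC[Se]c1nc(N)c2cccnc2n1` has not been measured in this assay. Compound 4 differs from compound 3 by pentyl in place of hydrogen on a selenium, the same change that turns compound 2 into compound 1, and the surroundings of the place are described in the same words for both pairs. The step of a 1.1-fold lower number from compound 3 to compound 4 (0.02 log units; within the scatter) is expected to be small, because the step of a 1.1-fold lower number from compound 2 to compound 1 (0.05 log units; within the scatter) was within the scatter. On that basis compound 4 is estimated at 42000 nM in this assay. The expected range for compound 4 runs from 25000 nM to 70000 nM.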

Compound 4, concentration for 50% growth inhibition: 8780 nM
Compound 4: middle estimate off by 4.8-fold (0.68 log units), on the high side, and the stated range ends above it.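

In this assay, pentyl in place of hydrogen on a selenium gives a 5.0-fold lower number from compound 3 to compound 4 (0.70 log units; beyond the scatter). Set beside the earlier step, the size of this change does not carry over from the core of compound 2 to the core of compound 3: the same change on two cores in this assay, a 1.1-fold lower number (0.05 log units; within the scatter) from compound 2 to compound 1 and a 5.0-fold lower number (0.70 log units; beyond the scatter) from compound 3 to compound 4, 4.5-fold (0.65 log units) apart, beyond the scatter of two such steps. This shows that the outcome of the change depends on the core it sits on, but with one pair per core and cores that differ in more than one place, it does not show which difference between them matters, nor does it give a rule for predicting the step on a further core.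

The compounds shown leave open whether a shorter chain such as ethyl or a longer chain such as octyl on the selenium would give steps that differ in the same way on the two cores. They also leave open whether a benzyl group on the selenium would follow pentyl on either core.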